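The source may report more compounds than this note shows. Statements on the series, on what has been measured and on what is new or still open speak of the compounds shown alone.

Of the compounds shown here, three sharing one core have been measured in an assay on membranes from HEK293 cells for displacement of a labelled ligand from adenosine receptor A2b (Homo sapiens), read by scintillation counting, with a stated time of 30 min; a lower number here means a stronger inhibitor, a higher number a weaker inhibitor. Compound 1 `CCCOC(=O)C1=C(C)NC(=O)NC1c1ccoc1` gives 1190 nM in this assay. Compound 2 `CCCOC(=O)C1=C(C)NC(=O)NC1c1cccs1` gives 1520 nM, and compound 3 `CC1=C(c2ncc(C)o2)C(c2ccoc2)NC(=O)N1` gives 801 nM. Compound 1 lies between the other two numbers, yet both neighbours stay within the usual scatter of it: the step of a 1.3-fold higher number from compound 1 to compound 2 (0.11 log units; within the scatter) and the step of a 1.5-fold lower number from compound 1 to compound 3 (0.17 log units; within the scatter) are each too small to count as a real change.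

Compound 4 `CC1=C(C(=O)OC2CCC2)C(c2ccoc2)NC(=O)N1` differs from compound 1 in one place: cyclobutyl in place of propyl on an oxygen next to a carbonyl group. The measured steps do not touch this part of the molecule. The step from compound 1 to compound 2 exchanges the aromatic ring on the saturated ring carbon, and the step from compound 1 to compound 3 replaces the whole propoxycarbonyl group with a ring; neither reports what a larger group on the ester oxygen does. Because both known steps were within the scatter, there is no indication of a strong response to small changes on this core, so for compound 4 no step beyond the scatter is expected in this assay, in either direction. The estimate for compound 4 is therefore 1000 nM, with a range from 400 nM to 2500 nM, meaning an expected step of a 1.2-fold lower number from compound 1 to compound 4 (0.08 log units; within the scatter).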

Compound 4, inhibition constant: 307 nM
Beside the measured number, compound 4's estimate is 3.3-fold (0.51 log units) above it; the whole stated range lies above it.
By their numbers in this assay, from the lowest: compound 4; then compounds 3, 1 and 2 (each within the scatter of the next).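

In this assay, among the compounds shown here, putting cyclobutyl in place of propyl on an oxygen next to a carbonyl group gives a 3.9-fold lower number from compound 1 to compound 4 (0.59 log units; beyond the scatter), and this is the first step on the shared core that lies beyond the scatter. For the compounds shown here, the position therefore responds to a fairly small edit, since an open propyl chain gives way to a four-membered ring of carbon only, with no hydrogen-bond donors or acceptors on either group and no net charge, and the earlier steps could not show this because neither of them compared groups on this oxygen. Nothing available here accounts for the difference between the chain and the ring.

The compounds shown leave open whether the ring itself matters or simply the extra carbon, a question that an open butyl chain, a branched isobutyl group or a cyclopentyl ring on the same oxygen would help to settle. They also leave open whether cyclobutyl has the same effect when thiophen-2-yl stands in place of furan-3-yl on the saturated ring carbon.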